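Ring amine variation on the aromatic carbon: compound 4

The source may hold more compounds than are shown below. What is called first, only, known or untested is meant among the compounds shown, and "the series" means these compounds.

The series is built on the core of compound 1, `CC(C(=O)NCc1ccc(C(F)(F)F)nc1)c1ccc(NS(C)(=O)=O)c(F)c1`; in a functional assay on CHO-K1 cells for antagonist activity at transient receptor potential cation channel subfamily V member 1 (Homo sapiens), read by FLIPR (a lower number here means a stronger inhibitor, a higher number a weaker inhibitor), compound 1 gives "not active" (no number reported). Compound 2, `CC(C(=O)NCc1ccc(C(F)(F)F)nc1N(C)C)c1ccc(NS(C)(=O)=O)c(F)c1`, carries dimethylamino on an aromatic carbon, and in this assay compound 2 gives 2390 nM. Compound 3, `CC(C(=O)NCc1ccc(C(F)(F)F)nc1N1CCCC1)c1ccc(NS(C)(=O)=O)c(F)c1`, carries pyrrolidin-1-yl at that carbon, and in this assay compound 3 gives 211 nM. For the measured compounds named here, of the two compounds with a number, compound 3 stands at the lower end; the single measured step, an 11-fold lower number from compound 2 to compound 3 (1.05 log units; beyond the scatter), separates it from compound 2, and compound 1 contributes no number.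

Compound 4, `COC1CCN(c2nc(C(F)(F)F)ccc2CNC(=O)C(C)c2ccc(NS(C)(=O)=O)c(F)c2)CC1`, is not yet measured. It differs from compound 3 in one place: 4-methoxypiperidin-1-yl in place of pyrrolidin-1-yl on an aromatic carbon. Going by the values given here, the one measured step bears on this change only loosely, since it set an acyclic amine against a cyclic one, whereas here one cyclic amine replaces another and a methoxy group enters. Among the compounds with values here, a further loss is not expected because an 11-fold lower number from compound 2 to compound 3 (1.05 log units; beyond the scatter) favoured the ring amine, but no measured pair tests the six-membered ring or the methoxy group, so the expected change is small, a 1.4-fold lower number from compound 3 to compound 4 (0.15 log units; within the scatter), within the scatter. Compound 4 is estimated at 150 nM, with a range from 40 nM to 600 nM.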

Compound 4, half-maximal inhibitory concentration: 280 nM
Compound 4: middle estimate off by 1.9-fold (0.27 log units), on the low side, within the range that was stated.
By their numbers in this assay, from the lowest: compounds 3 and 4 (each within the scatter of the next); then compound 2.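

Notes on the position next to the ring nitrogen: in this assay, this aromatic carbon accepts 4-methoxypiperidin-1-yl, with 8 heavy atoms and a second hydrogen-bond acceptor, in place of pyrrolidin-1-yl, with no shift beyond the scatter: a 1.3-fold higher number from compound 3 to compound 4 (0.12 log units; within the scatter). The gain over dimethylamino is therefore not confined to the five-membered ring, as the six-membered ring amine also stands clear of the acyclic amine, with an 8.5-fold lower number from compound 2 to compound 4 (0.93 log units; beyond the scatter), although the ring size and the methoxy group enter together and these compounds cannot separate their contributions. No measurement shown accounts for how these amines differ in this assay.

The compounds shown leave open how piperidin-1-yl without the methoxy group, morpholin-4-yl, or a ring amine carrying a hydroxyl group or a carboxylic acid would read at this carbon. Also open, on these data alone, is whether a longer acyclic amine such as diethylamino would stay with dimethylamino or move towards the ring amines, which would show whether the ring itself matters.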